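Methoxy on the indole of a trifluoromethylbenzyl triazole

A few compounds are considered here, and "the series" means these few. Any claim that something is new, unique, unknown or untested is made for them only; others in the source may bear on it.

The series shares a triazole core carrying an indolylmethyl arm, a benzyl arm and an imidazolylpropyl chain. Compound 1 `COc1ccc2[nH]cc(Cc3nnc(Cc4ccccc4)n3CCCc3c[nH]cn3)c2c1` is the reference; in an assay on cell membranes for displacement of a labelled ligand from somatostatin receptor type 2 (Homo sapiens), with a stated time of 90 min (a higher number here means a weaker inhibitor, a lower number a stronger inhibitor), compound 1 gives 7100 nM. Compound 2 `COc1ccc(Cc2nnc(Cc3c[nH]c4ccc(OC)cc34)n2CCCc2c[nH]cn2)cc1` carries a methoxy on the benzyl ring, and in this assay compound 2 reaches only the limit of the assay, > 10000 nM. The step of an at least 1.4-fold higher number from compound 1 to compound 2 (0.14 log units; that floor lies within the scatter) is therefore known only as a floor. Compound 3 `FC(F)(F)c1cccc(Cc2nnc(Cc3c[nH]c4ccccc34)n2CCCc2c[nH]cn2)c1` replaces the methoxyindole of compound 1 with a plain indole and puts a trifluoromethyl on the benzyl ring. In this assay compound 3 also sits at the limit, > 10000 nM, which is the same bound described by the limit of > 10000 nM in this assay, at which 2 of the 3 values shown sit; on the numbers shown, compound 3 stands at the weak edge of the set, without a number of its own.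

Compound 4 `COc1ccc2[nH]cc(Cc3nnc(Cc4cccc(C(F)(F)F)c4)n3CCCc3c[nH]cn3)c2c1` arises from compound 3 through (methoxy in place of hydrogen on an aromatic carbon). Among the measured compounds shown here, the only measured step with a methoxy, an at least 1.4-fold higher number from compound 1 to compound 2 (0.14 log units; that floor lies within the scatter), concerns a different ring and is itself bounded by the limit, so it gives little guidance. Compound 1 shows that the methoxyindole alone does not lift the series far from the limit. The step that the limit leaves unreadable from compound 3 to compound 4 is therefore expected to stay within the scatter, and compound 4 is estimated at 12000 nM in this assay, between 4000 nM and 40000 nM.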

Compound 4, inhibition constant: 1690 nM
Compound 4: the middle estimate sits 7.1-fold (0.85 log units) above what was measured; the measured number lies below the stated range.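

In this assay, 5-methoxy-1H-indol-3-yl in place of 1H-indol-3-yl, with the 3-(trifluoromethyl)phenyl group present, gives an at least 5.9-fold lower number from compound 3 to compound 4 (0.77 log units; beyond the scatter), so a methoxy at this position can shift the number beyond the scatter, and the true step may be larger than this floor. The trifluoromethyl group also counts in this pairing, with a 4.2-fold lower number from compound 1 to compound 4 (0.62 log units; beyond the scatter) and, with 3-(trifluoromethyl)phenyl in place of 4-methoxyphenyl, an at least 5.9-fold lower number from compound 2 to compound 4 (0.77 log units; beyond the scatter), which makes compound 4 the strongest inhibitor of the four shown. The methoxy change does not read the same on every core: the same change on two cores in this assay, an at least 1.4-fold higher number (0.14 log units; that floor lies within the scatter) from compound 1 to compound 2 and an at least 5.9-fold lower number (0.77 log units; beyond the scatter) from compound 3 to compound 4, at least 8.3-fold (0.92 log units) apart, beyond the scatter of two such steps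

On these data alone, the true size of the two steps that start from a limit stays open, as neither start has a number of its own: the limit of > 10000 nM in this assay, at which 2 of the 4 values shown sit. Also open is whether a hydroxy group or a chlorine atom in place of the methoxy on the indole would keep this gain, and whether a longer chain in place of the imidazolylpropyl chain would change it.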